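Nitro in place of methyl: a small expected step

The source may report more compounds than this note shows. Statements on the series, on what has been measured and on what is new or still open speak of the compounds shown alone.

In a functional assay on NCI-H460 cells (Homo sapiens) for cytotoxicity, read by sulforhodamine B assay, with a stated time of 3 days (a higher number here means a weaker inhibitor, a lower number a stronger inhibitor), compound 1 `OCc1cn(Cc2ccc(Cl)cc2)c2ccccc12` gives 16 nM, compound 2 `OCc1cn(Cc2ccc(Br)cc2)c2ccccc12` gives 31 nM, and compound 3 `Cc1ccc(Cn2cc(CO)c3ccccc32)cc1` gives 31 nM. Compound 3 thus stands level with compound 2 and within the usual scatter of compound 1.

The next structure, compound 4 `O=[N+]([O-])c1ccc(Cn2cc(CO)c3ccccc32)cc1`, has nitro in place of methyl on an aromatic carbon, para to a large group: nitro in place of methyl on an aromatic carbon.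

For the measured compounds named here, three measured steps bear on this change, since each swaps the group at that same place. Bromo in place of chloro gives a 1.9-fold higher number from compound 1 to compound 2 (0.29 log units; within the scatter), methyl in place of chloro gives a 1.9-fold higher number from compound 1 to compound 3 (0.29 log units; within the scatter), and methyl in place of bromo gives no change at the digits printed from compound 2 to compound 3 (within the scatter). All three stay within the scatter, but none of them involves nitro, so the guide is a limited one. No step beyond the scatter is expected in this assay, and the estimated step is a 1.1-fold higher number from compound 3 to compound 4 (0.05 log units; within the scatter). For compound 4 the estimate is 35 nM, with an expected range of 10 nM to 120 nM.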

Compound 4, half-maximal inhibitory concentration: 79 nM
Beside the measured number, compound 4's estimate is 2.3-fold (0.35 log units) below it; measured number inside the range.
By their numbers in this assay, from the lowest: compounds 1, 2 and 3 (each within the scatter of the next); then compound 4.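

Chloro, bromo and methyl could not be told apart at this place in this assay, so the position had looked indifferent to which of these groups it carried. Nitro is the first group shown to move the result beyond the scatter, giving a weaker inhibitor than each of the other three, though only modestly so (a 2.5-fold higher number from compound 3 to compound 4 (0.41 log units; beyond the scatter); a 2.5-fold higher number from compound 2 to compound 4 (0.41 log units; beyond the scatter); a 4.9-fold higher number from compound 1 to compound 4 (0.69 log units; beyond the scatter)). Nothing measured here accounts for this shift.

The compounds shown leave open how an amine, a carboxylic acid or a methoxy group would fare at this place, and so whether the shift belongs to nitro alone or is shared by other groups containing nitrogen or oxygen. A longer chain at this place also remains an open case.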